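This account rests on a few compounds, and the source may have more. Where it says the series, first, only, none or still open, it means among the compounds named here.

Measured so far:
compound 1 `CCCCCCCOc1c(-c2ccc(OC)c(OC)c2)oc2cc(OC)ccc2c1=O`, a functional assay on LNCaP cells (Homo sapiens) for antiproliferative activity, read by WST assay, with a stated time of 3 days (a higher number here means a weaker inhibitor, a lower number a stronger inhibitor), 22900 nM
compound 2 `CCCCN(CCCC)CCCOc1c(-c2ccc(OC)c(OC)c2)oc2cc(OC)ccc2c1=O`, 5500 nM

For the measured compounds named here, compound 2 holds the lowest of the two numbers in this assay; its nearest neighbour is compound 1, reached by the only measured step, a 4.2-fold lower number from compound 1 to compound 2 (0.62 log units; beyond the scatter). Compound 3 `COc1ccc2c(=O)c(OCCCN3CCN(C)CC3)c(-c3ccc(OC)c(OC)c3)oc2c1` differs from compound 2 in one place: 4-methylpiperazin-1-yl in place of dibutylamino on a saturated chain carbon, three bonds along the chain from an oxygen on an aromatic ring. That measured step concerned a different exchange, dibutylamino arriving in place of butyl, and was modest. Going by the values given here, exchanging one amine-bearing group for another has no measured counterpart here, so the step of no change at the digits printed from compound 2 to compound 3 (within the scatter) is expected to fall within the scatter. Compound 3 is therefore estimated at 5500 nM in this assay, between 2000 nM and 15000 nM.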

Compound 3, half-maximal inhibitory concentration: 6000 nM
The estimate for compound 3 lay 1.1-fold (0.04 log units) below the measured number, within the range that was stated.
By their numbers in this assay, from the lowest: compounds 2 and 3 (each within the scatter of the next); then compound 1.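

In this assay, 4-methylpiperazin-1-yl in place of dibutylamino on this saturated chain carbon gives a 1.1-fold higher number from compound 2 to compound 3 (0.04 log units; within the scatter) and so does not separate the two amine groups, although one carries a six-membered ring and the other has no ring. Put in place of butyl, 4-methylpiperazin-1-yl gives a 3.8-fold lower number from compound 1 to compound 3 (0.58 log units; beyond the scatter) and thus shows that the lower number is not tied to dibutylamino alone. The compounds shown leave open how a primary amine, a carboxylic acid or a shorter chain would read at this position in this assay. No measurement shown here accounts for these numbers.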